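The source may report more compounds than this note shows. Statements on the series, on what has been measured and on what is new or still open speak of the compounds shown alone.

Among the measured compounds shown here, in a physicochemical assay for solubility, measured as kinetic solubility (a higher number here means a more soluble compound, a lower number a less soluble compound), only two compounds have numbers so far. Compound 1 (`Cc1ccc(Oc2cc(C(=O)Nc3cnc(C)cn3)cc3oc(C)cc23)cc1`) gives 18000 nM and compound 2 (`Cc1cc2c(Oc3cnc(C(=O)N4CC(C)(C)C4)cn3)cc(C(=O)Nc3cnccn3)cc2o1`) gives 78000 nM as the higher number of the two, a gap that lies beyond the scatter of repeated measurements. The next compound to be measured is compound 3 (`Cc1cc2c(Oc3cnc(C(=O)N(C)C)cn3)cc(C(=O)Nc3cnccn3)cc2o1`), and the account follows the step to it from compound 2. The structural change is dimethylamino in place of 3,3-dimethylazetidin-1-yl on a carbonyl carbon and it places dimethylamino in place of 3,3-dimethylazetidin-1-yl on a carbonyl carbon, with the rest of the structure unchanged. For the measured compounds named here, no two measured compounds differ in one place only, so the data give no direct guide to the size of such a step. The expectation therefore starts from compound 2 at 78000 nM and allows only a modest move. A slight upward step is expected, and the estimated 1.3-fold higher number from compound 2 to compound 3 (0.11 log units; within the scatter) in this assay would stay within the scatter. For compound 3 the estimated value is 100000 nM with an expected range of 50000 nM to 190000 nM for repeat measurements.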

Compound 3, solubility: 30000 nM
Beside the measured number, compound 3's estimate is 3.3-fold (0.52 log units) above it; the measured number lies below the stated range.
By their numbers in this assay, from the lowest: compounds 1 and 3 (each within the scatter of the next); then compound 2.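

In this assay, among the compounds shown here, placing dimethylamino in place of 3,3-dimethylazetidin-1-yl on a carbonyl carbon gives a 2.6-fold lower number from compound 2 to compound 3 (0.41 log units; beyond the scatter), the first comparison here between two compounds that differ in one place. It shows that the number is sensitive to the group at this position: a swap that leaves the rest of the structure unchanged and adds no hydrogen-bond donor or acceptor still produces a step beyond the scatter, with the ring-bearing group of six heavy atoms on the higher side and the open group of three on the lower. Nothing available explains the step.

On these data alone, this single pair cannot separate the presence of the four-membered ring from the number of heavy atoms, so it remains open whether unsubstituted azetidin-1-yl, pyrrolidin-1-yl or diethylamino on the same carbonyl carbon would fall with compound 2 or with compound 3. As far as these compounds go, it is also open how groups that add a further hetero atom, such as morpholin-4-yl or piperazin-1-yl, would read at this position, and whether the step would keep its size with a different group elsewhere on the shared core.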